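Swapping a Methoxy for Phenyl on a Three-Compound Series

The source may report more compounds than this note shows. Statements on the series, on what has been measured and on what is new or still open speak of the compounds shown alone.

Compound 1: `COc1ccccc1-c1cc(-c2ccc([N+](=O)[O-])cc2)[nH]n1`, 11700 nM
Compound 2: `COc1ccc(-c2cc(-c3ccc(C(F)(F)F)cc3)n[nH]2)cc1`, 22800 nM
Compound 3: `COc1ccc(-c2cc(-c3ccc4ccccc4c3)n[nH]2)cc1`, 17500 nM

Of the compounds shown here, three share a core and have been tested in a functional assay on OVCAR cells (Homo sapiens) for inhibition, read by MTT assay, with a stated time of 48 h; a higher number here means a weaker inhibitor of growth, a lower number a stronger inhibitor of growth. Compound 1 gives the lowest of the three numbers, 11700 nM. Compound 3 gives 17500 nM and compound 2 gives 22800 nM, and both of those gaps to compound 1 fall within the usual scatter of this assay, so the three cannot be ranked against one another on these numbers alone.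

The next compound, compound 4 with structure `O=[N+]([O-])c1ccc(-c2cc(-c3ccccc3-c3ccccc3)n[nH]2)cc1`, is made from compound 1 by a single change: phenyl in place of methoxy on an aromatic carbon. The methoxy that sits ortho to a large group in compound 1 is exchanged for a phenyl in the same place. Among the compounds with values here, no pair among the measured compounds shows such a change, so there is no measured step on which to rest an expectation. In this assay, the three measured values lie close together despite rather different substituents, which suggests that compound 4 may also land near compound 1, with no step beyond the scatter expected in either direction. On that basis the step from compound 1 to compound 4 is estimated at a 1.1-fold higher number from compound 1 to compound 4 (0.05 log units; within the scatter). Compound 4 is therefore expected to give about 13000 nM in this assay, within a range from 4000 nM to 40000 nM.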

Compound 4, concentration for 50% growth inhibition: 3400 nM
Beside the measured number, compound 4's estimate is 3.8-fold (0.58 log units) above it, outside the stated range (below it).
By their numbers in this assay, from the lowest: compound 4; then compounds 1, 3 and 2 (each within the scatter of the next).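

In this assay, within the data shown here, phenyl in place of methoxy on an aromatic carbon, ortho to a large group, gives a 3.4-fold lower number from compound 1 to compound 4 (0.54 log units; beyond the scatter) and is the first step to lie beyond the scatter. The earlier compounds shown here offered no such pair, and this step shows that the number responds to what sits at this position: a group of 2 heavy atoms with 1 hydrogen-bond acceptor gives way to a six-membered aromatic ring of 6 carbon atoms with no acceptor, and the larger group gives the lower number. Nothing shown here gives a reason for this step.

A single pair cannot separate the arrival of the ring from the departure of the oxygen, so a cyclohexyl ring, a longer chain such as butyl, or an amine on the same carbon would be needed to tell these apart. From the compounds shown here alone, it also remains open whether the same exchange would lower the number in the same way on compound 2 or compound 3.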